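From furan-2-yl to 5-methylthiophen-2-yl at the tolerance limit

A few compounds are considered here, and "the series" means these few. Any claim that something is new, unique, unknown or untested is made for them only; others in the source may bear on it.

In an ADME assay on THP-1 cells (Homo sapiens) for cytotoxicity, read by MTT assay (a higher number here means that more compound is tolerated, a lower number that less compound is tolerated), compound 1 `Clc1ccc(-c2nc(C(Cl)(Cl)Cl)nc3ccccc23)cc1` gives > 500000 nM, which is a limit of the assay. Compound 2 `ClC(Cl)(Cl)c1nc(-c2ccco2)c2ccccc2n1` gives > 500000 nM, again a limit and not a number. Within the data shown here, the one measured step, a step that the two limits leave unreadable from compound 1 to compound 2, therefore has no readable size, and both values rest on (the limit of > 500000 nM in this assay, at which 2 of the 2 values shown sit). In compound 3 `Cc1ccc(-c2nc(C(Cl)(Cl)Cl)nc3ccccc23)s1`, 5-methylthiophen-2-yl takes the place of furan-2-yl on an aromatic carbon (5-methylthiophen-2-yl in place of furan-2-yl on an aromatic carbon). Among the measured compounds shown here, with no sized step to draw on, no change beyond the scatter is expected in this assay. The estimated step is a number no higher from compound 2 to compound 3 (the limit leaves the size open). The estimated value for compound 3 is 500000 nM, expected to lie between 150000 nM and 1000000 nM.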

Compound 3, concentration lethal to 50% of the cells: 125000 nM
For compound 3 the middle estimate is 4.0-fold (0.60 log units) above the measured one; measured number below the stated range.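

Among these compounds, with 5-methylthiophen-2-yl, compound 3 is the first compound here to give a readable number in this assay, which shows that a change at this position can lower the tolerated concentration. The change from furan-2-yl is an at least 4.0-fold lower number from compound 2 to compound 3 (0.60 log units; beyond the scatter), and the change from 4-chlorophenyl is an at least 4.0-fold lower number from compound 1 to compound 3 (0.60 log units; beyond the scatter). Both sizes stay open on one side because each starting value is a limit: the limit of > 500000 nM in this assay, at which 2 of the 3 values shown sit.

The compounds shown leave open whether the ring sulfur or the methyl group accounts for the shift. They also leave open how an amine or a longer chain at this position would behave.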